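The source may hold more compounds than are shown below. What is called first, only, known or untested is meant among the compounds shown, and "the series" means these compounds.

Measured in an ADME assay on L02 cells (Homo sapiens) for cytotoxicity, read by MTT assay, with a stated time of 24 h; a lower number here means a stronger inhibitor, a higher number a weaker inhibitor:
- compound 1 `COc1cc(/C=C2\CN(S(=O)(=O)c3ccc(F)cc3)C/C(=C\c3ccccc3F)C2=O)cc(OC)c1`: 18500 nM
- compound 2 `COc1cc(/C=C2\CN(S(=O)(=O)c3ccc(F)cc3)C/C(=C\c3cccc([N+](=O)[O-])c3)C2=O)cc(OC)c1OC`: 18800 nM
- compound 3 `COc1cc(/C=C2\CN(S(=O)(=O)c3ccc(F)cc3)C/C(=C\c3ccc(C#N)cc3)C2=O)cc(OC)c1OC`: 12900 nM

Compound 3, at 12900 nM, sits within the usual scatter of both other compounds, so the three numbers cannot be ranked. Compound 4 `COc1cc(/C=C2\CN(S(=O)(=O)c3ccc(F)cc3)C/C(=C\c3cc(OC)c(OC)c(OC)c3)C2=O)cc(OC)c1` has not yet been measured. It departs from compound 3 by one change: 3,5-dimethoxyphenyl in place of 4-cyanophenyl on a double-bonded chain carbon bound to a double-bonded ring carbon. Among the measured compounds shown here, only one measured step exchanges a group at this place, a 1.5-fold lower number from compound 2 to compound 3 (0.16 log units; within the scatter). That step, 4-cyanophenyl in place of 3-nitrophenyl, stays within the scatter. Compound 1, which also carries 3,5-dimethoxyphenyl on the shared core, gives 18500 nM, a value within the scatter of compound 3. For the measured compounds named here, no measured step shows what 3,5-dimethoxyphenyl does at this place, so the support is thin, and no step beyond the scatter is expected in this assay, in either direction. The expected change is a 1.2-fold higher number from compound 3 to compound 4 (0.07 log units; within the scatter). For compound 4 the estimated value is 15000 nM, with an expected range from 8000 nM to 28000 nM.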

Compound 4, half-maximal inhibitory concentration: 12300 nM
Beside the measured number, compound 4's estimate is 1.2-fold (0.09 log units) above it, within the range that was stated.
By their numbers in this assay, from the lowest: compounds 4, 3, 1 and 2 (each within the scatter of the next).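

In this assay, among the compounds shown here, 3,5-dimethoxyphenyl on a double-bonded chain carbon bound to a double-bonded ring carbon stays within the scatter of 4-cyanophenyl (a 1.0-fold lower number from compound 3 to compound 4 (0.02 log units; within the scatter)) and of 3-nitrophenyl (a 1.5-fold lower number from compound 2 to compound 4 (0.18 log units; within the scatter)), which gives the first measured steps for this group at this place. The step with 3,4,5-trimethoxyphenyl in place of 2-fluorophenyl (a 1.5-fold lower number from compound 1 to compound 4 (0.18 log units; within the scatter)) also stays within the scatter, so no step listed for this place among the four compounds goes beyond it. No measured evidence accounts for these numbers.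

Every group shown at this place is built on a six-membered aromatic ring of carbon only. On these data alone, whether an amine, a carboxylic acid or a longer chain at this place would move the number beyond the scatter remains open.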